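Methyl to 4-Fluorobenzyl: Expected Effect on Cell Cytotoxicity

A few compounds are considered here, and "the series" means these few. Any claim that something is new, unique, unknown or untested is made for them only; others in the source may bear on it.

Four compounds share a core and differ in two places. Compound 1 `COc1cc(-c2nnc(SC)n2/N=C/c2ccccc2)cc(OC)c1OC` carries a methylsulfanyl group and a phenyl on the carbon with a double bond to nitrogen. In a functional assay on HT-29 cells (Homo sapiens) for cytotoxicity, read by MTT assay, with a stated time of 48 h (on this read-out lower numbers stand for stronger inhibition and higher numbers for weaker inhibition), compound 1 gives > 200000 nM, which is a limit of the assay and not a number. Compound 2 `COc1cc(-c2nnc(SCc3ccc(F)cc3)n2/N=C/c2ccccc2)cc(OC)c1OC` differs from compound 1 by 4-fluorophenyl in place of hydrogen on a saturated chain carbon bound to a sulfur. In this assay compound 2 gives > 200000 nM, again a limit of the assay rather than a number. The step that the two limits leave unreadable from compound 1 to compound 2 cannot be read because both values sit at the limit of > 200000 nM in this assay, at which 2 of the 3 values shown sit.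

Compound 3 `COc1ccc(/C=N/n2c(SC)nnc2-c2cc(OC)c(OC)c(OC)c2)c(OC)c1` differs from compound 1 by 2,4-dimethoxyphenyl in place of phenyl on a carbon with a double bond to nitrogen. In this assay, among the measured compounds shown here, compound 3 gives 144000 nM, the only true number among the three measured compounds. The step of an at least 1.3-fold lower number from compound 1 to compound 3 (0.14 log units; that floor lies within the scatter) shows that compound 3 is at least slightly more potent than compound 1, though the floor of that step lies within the usual scatter.

Compound 4 `COc1ccc(/C=N/n2c(SCc3ccc(F)cc3)nnc2-c2cc(OC)c(OC)c(OC)c2)c(OC)c1` has not been measured. It differs from compound 3 by 4-fluorophenyl in place of hydrogen on a saturated chain carbon bound to a sulfur, the same change that turns compound 1 into compound 2. The step from compound 1 to compound 2 is hidden by the limits. The expected step of a 1.0-fold higher number from compound 3 to compound 4 (0.02 log units; within the scatter) is therefore taken to be small, resting on the value of compound 3 at 144000 nM. Compound 4 is therefore expected to give about 150000 nM, with a plausible range from 40000 nM to 500000 nM in this assay.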

Compound 4, half-maximal inhibitory concentration: 126000 nM
Compound 4: middle estimate off by 1.2-fold (0.08 log units), on the high side; measured number inside the range.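

Replacing phenyl with 2,4-dimethoxyphenyl on a carbon with a double bond to nitrogen gives an at least 1.5-fold lower number from compound 2 to compound 4 (0.20 log units; that floor lies within the scatter) in this assay, and set beside the earlier case, the comparison reads: the same change on two cores in this assay, an at least 1.3-fold lower number (0.14 log units; that floor lies within the scatter) from compound 1 to compound 3 and an at least 1.5-fold lower number (0.20 log units; that floor lies within the scatter) from compound 2 to compound 4; the limit leaves it open whether they differ. The change therefore points the same way on both cores, but neither step has a firm size, and a match in size between the two cores is not established, since each step starts from a limit of the assay rather than a number: the limit of > 200000 nM in this assay, at which 2 of the 4 values shown sit. The other change, 4-fluorophenyl in place of hydrogen on a saturated chain carbon bound to a sulfur, gives a 1.1-fold lower number from compound 3 to compound 4 (0.06 log units; within the scatter), so it shows no real difference on this core, while the same step on the core of compound 1 cannot be read.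

The compounds shown leave open whether a longer chain or a chain ending in an amine, in place of methyl or 4-fluorobenzyl, would change the read-out beyond the usual scatter. They also leave open what a carboxylic acid would do on the carbon with a double bond to nitrogen, where only phenyl and 2,4-dimethoxyphenyl appear here.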